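Acetyl pyrazole amide to tert-butyl pyrazole urea

A few compounds are considered here, and "the series" means these few. Any claim that something is new, unique, unknown or untested is made for them only; others in the source may bear on it.

Compound 1 `CC(=O)c1cc(C(=O)N[C@@H](C)Cn2ccc(-c3cc(F)c(C#N)c(Cl)c3)n2)n[nH]1` in an ADME assay on PC-3 cells (Homo sapiens) for cytotoxicity, read by CCK-8 assay, with a stated time of 6 days; a lower number here means a stronger inhibitor, a higher number a weaker inhibitor: > 30000 nM, a limit of the assay rather than a number.
Compound 2 `CC(=O)c1cc(C(=O)N[C@H](C)Cn2ccc(-c3cc(F)c(C#N)c(Cl)c3)n2)n[nH]1` in this assay: "not determined" (no result reported).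
Compound 3 `CC(O)c1ccc(C(=O)N[C@@H](C)Cn2ccc(-c3ccc(C#N)c(Cl)c3)n2)cc1` in this assay: > 30000 nM, likewise a limit.

Compound 1 thus stands at the limit where both reported values sit (the limit of > 30000 nM in this assay, at which 2 of the 3 values shown sit); compound 2 differs from it only in the configuration as drawn the fact that compounds 1 and 2 differ only in the configuration as drawn and gives no value. No measured pair differing in one place exists among these three, so no step size is known here. Compound 4 `C[C@@H](Cn1ccc(-c2cc(F)c(C#N)c(Cl)c2)n1)NC(=O)Nc1cc(C(C)(C)C)[nH]n1` differs from compound 1 by (5-(tert-butyl)-1H-pyrazol-3-yl)amino in place of 5-acetyl-1H-pyrazol-3-yl on a carbonyl carbon. In this assay the step from compound 1 to compound 4 a number no higher from compound 1 to compound 4 (the limit leaves the size open) is expected to stay within the scatter, with compound 4 most likely again reported as a limit. Compound 4 is estimated at 30000 nM, in a range from 10000 nM to 100000 nM.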

Compound 4, half-maximal inhibitory concentration: > 30000 nM
Compound 4 gave a limit, no number; the forecaster's own chance of this, stated with the estimate: 80%; the middle value lies on the limit itself.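

Compound 1 and compound 4 are both reported only as limits in this assay, and the step between them cannot be read. The compounds shown leave open whether (5-(tert-butyl)-1H-pyrazol-3-yl)amino in place of 5-acetyl-1H-pyrazol-3-yl changes the read-out at all.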